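Swapping the basic end group on the chain of compound 2

The source may hold more compounds than are shown below. What is called first, only, known or untested is meant among the compounds shown, and "the series" means these compounds.

Measured so far:
- compound 1 `CN(C)CCCCn1c2c(c3ccccc31)C(=O)c1c[n+]([O-])c3ccccc3c1C2=O`: 520 nM
- compound 2 `CN1CCN(CCCCn2c3c(c4ccccc42)C(=O)c2c[n+]([O-])c4ccccc4c2C3=O)CC1`: 100 nM

In a toxicity assay on HEK-293T cells (Homo sapiens) for cytotoxicity, read by MTT assay, with a stated time of 72 h (a lower number here means a stronger inhibitor, a higher number a weaker inhibitor), compound 2 has the lowest number of the two measured compounds; its nearest neighbour is compound 1, and the step of a 5.2-fold lower number from compound 1 to compound 2 (0.72 log units; beyond the scatter) lies beyond the scatter. Compound 3 `O=C1c2c[n+]([O-])c3ccccc3c2C(=O)c2c1c1ccccc1n2CCCN1CCC(O)CC1` has not yet been measured. It differs from compound 2 by 4-hydroxypiperidin-1-yl in place of (4-methylpiperazin-1-yl)methyl on a saturated chain carbon, three bonds along the chain from an aromatic nitrogen. Among the measured compounds shown here, the one measured step that bears on this, a 5.2-fold lower number from compound 1 to compound 2 (0.72 log units; beyond the scatter), shows that changing the amine at the far end of the chain can move the number by a modest amount in either direction. Here the ring changes again and the chain is one unit shorter; no measured pair covers either of these on its own. A small step back toward the number of compound 1 is therefore expected, with the estimate for compound 3 at 200 nM (range 80 nM to 500 nM), which corresponds to an expected step of a 2.0-fold higher number from compound 2 to compound 3 (0.30 log units; within the scatter).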

Compound 3, half-maximal inhibitory concentration: 170 nM
Beside the measured number, compound 3's estimate is 1.2-fold (0.07 log units) above it; the range from low to high includes it.
By their numbers in this assay, from the lowest: compounds 2 and 3 (each within the scatter of the next); then compound 1.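

In this assay, a second ring-bearing end group, this time carrying a hydroxyl group on a shorter chain, gives a 1.7-fold higher number from compound 2 to compound 3 (0.23 log units; within the scatter), so 4-methylpiperazin-1-yl is not the only ring end that reaches this range. Set against the open-chain dimethylamino end, the new group gives a 3.1-fold lower number from compound 1 to compound 3 (0.49 log units; beyond the scatter), which means that both ring-bearing compounds shown lie on the lower side of compound 1, with no compound going against this among the three. No separate measurement is available to explain these numbers.

The ring end and the chain length change together here, so the compounds shown cannot divide the result between them. A 4-(4-hydroxypiperidin-1-yl)butyl chain or a 3-(4-methylpiperazin-1-yl)propyl chain would separate the two, and a morpholine or unsubstituted piperidine ring would test the role of the hydroxyl group.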